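The compounds below may be only part of what the source reports. "The series", "measured", "known", "first", "only" and "open" are said of these compounds alone.

Measured so far in an ADME assay on HEL cells (Homo sapiens) for cytotoxicity, with a stated time of 3 days; a lower number here means that less compound is tolerated, a higher number that more compound is tolerated: compound 1 `Cc1cc(-c2ccc(C=O)cc2)cn2c(CSCCc3ccccc3)cnc12` gives 100 ug/mL; compound 2 `Cc1cc(-n2ccc3cccnc32)cn2c(CSCCc3ccccc3)cnc12` gives 20 ug/mL.

Within the data shown here, compound 2 holds the lower of the two numbers, and the only step measured is a 5.0-fold lower number from compound 1 to compound 2 (0.70 log units; beyond the scatter). Compound 3 `Cc1cc(Sc2ccc(O)cc2)cn2c(CSCCc3ccccc3)cnc12` differs from compound 2 as follows: a group of 8 heavy atoms (6 carbon, 1 oxygen, 1 sulfur; one six-membered aromatic ring of carbon only) in place of a group of 9 heavy atoms (7 carbon, 2 nitrogen; one five-membered aromatic ring with 1 hetero atom, one six-membered aromatic ring with 1 hetero atom), on an aromatic carbon. Among the measured compounds shown here, the entering group, like the one carried by compound 1, is built on a six-membered aromatic ring of carbon only, so the step from compound 1 to compound 2, read in reverse, is the one that bears on this change. A rise beyond the scatter is therefore expected, estimated as a 3.0-fold higher number from compound 2 to compound 3 (0.48 log units; beyond the scatter). Compound 3 is estimated at 60 ug/mL, within a range of 20 ug/mL to 100 ug/mL.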

Compound 3, minimum cytotoxic concentration: 4 ug/mL
Compound 3: the middle estimate sits 15-fold (1.18 log units) above what was measured, outside the stated range (below it).
By their numbers in this assay, from the lowest: compound 3; then compound 2; then compound 1.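

In this assay the number keeps falling as this group on the aromatic carbon changes (a 5.0-fold lower number from compound 2 to compound 3 (0.70 log units; beyond the scatter)), and the span over the three compounds is wide (a 25-fold lower number from compound 1 to compound 3 (1.40 log units; beyond the scatter)). A six-membered aromatic ring of carbon only does not by itself hold the number high: 4-formylphenyl in compound 1 and (4-hydroxyphenyl)sulfanyl in compound 3 both carry one, yet they stand at opposite ends of the order. Nothing measured here accounts for the difference.

From the compounds shown here alone, the sulfur link and the hydroxyl enter together in compound 3, so their separate shares remain open. Going by these compounds, how an amine or a carboxylic acid on that ring would read also remains open.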